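The source may report more compounds than this note shows. Statements on the series, on what has been measured and on what is new or still open speak of the compounds shown alone.

Measured so far:
compound 1 `Cc1ccc(-c2n[nH]cc2N2CCCNCC2)cc1` — 1320 nM
compound 2 `COc1ccc(-c2n[nH]cc2N2CCCNCC2)cc1` — > 10000 nM

In an assay on isolated protein for binding affinity to 5-hydroxytryptamine receptor 6 (Homo sapiens) (on this read-out higher numbers stand for weaker inhibition and lower numbers for stronger inhibition), compound 1 gives 1320 nM. For compound 2 this assay returns only a limit, > 10000 nM. Compound 2 therefore sits at the limit of > 10000 nM in this assay, at which 1 of the 2 values shown sits, and its true value is not known. Going by the values given here, the single step measured so far is an at least 7.5-fold higher number from compound 1 to compound 2 (0.87 log units; beyond the scatter), the exchange of methyl for methoxy, and it moves toward weaker binding by a size that can only be bounded from below.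

Compound 3 `c1ccc(-c2n[nH]cc2N2CCCNCC2)cc1` is the next member. The change from compound 2 is hydrogen in place of methoxy on an aromatic carbon. Among the compounds with values here, no measured step covers hydrogen at this position, so the only bearing comes from the methyl-to-methoxy step: it shows that the methoxy group is the substituent associated with the weak end of the series, and its removal is expected to reverse at least part of that loss. Whether a bare hydrogen reaches the level of compound 1 cannot be told from two points. The expected step is an at least 4.0-fold lower number from compound 2 to compound 3 (0.60 log units; beyond the scatter), toward a lower number. Compound 3 is expected to give about 2500 nM in this assay, with a range of 800 nM to 9000 nM.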

Compound 3, inhibition constant: 3480 nM
Compound 3: middle estimate off by 1.4-fold (0.14 log units), on the low side, and the stated range covers the measured number.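

In this assay, removing the methoxy group from this position, para to a large group, gives an at least 2.8-fold lower number from compound 2 to compound 3 (0.45 log units; beyond the scatter), so at least part of the loss seen with methoxy is undone by a bare hydrogen. Hydrogen does not restore the level of the methyl compound, however: the exchange gives a 2.6-fold higher number from compound 1 to compound 3 (0.42 log units; beyond the scatter), which means that methyl is better than hydrogen here and that the position responds to more than the absence of methoxy. The three groups now fall in the order methyl, hydrogen, methoxy from lower to higher number, each step beyond the scatter, but the methoxy end stays open-ended because compound 2 is a limit and not a number: the limit of > 10000 nM in this assay, at which 1 of the 3 values shown sits.

From the compounds shown here alone, whether the gain from methyl carries over to ethyl, isopropyl or a halogen such as chlorine remains open, as does whether a hydroxyl or an amine at this position would fall toward the methoxy end of the order. The three compounds also say nothing about how changes elsewhere on the shared core would interact with this position.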